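Shifting the Oxygen Further Out Along the Side Chain

This account rests on a few compounds, and the source may have more. Where it says the series, first, only, none or still open, it means among the compounds named here.

Compound 1 `COC[C@H](C(C)C)C(c1ccc(O)c(OC)c1)c1ccc(O)c(OC)c1` holds the higher of the two clean numbers in a functional assay on HeLa cells (Homo sapiens) for cytotoxicity, read by WST assay, with a stated time of 48 h (on this read-out higher numbers stand for weaker inhibition and lower numbers for stronger inhibition), where compound 1 gives 76000 nM. Compound 2 `COc1cc(C(c2ccc(O)c(OC)c2)[C@@H](C)C(C)C)ccc1O` gives 19000 nM, the step being a 4.0-fold lower number from compound 1 to compound 2 (0.60 log units; beyond the scatter). Compound 3 `COc1cc(C(c2ccc(O)c(OC)c2)[C@@H](CO)C(C)C)ccc1O` reaches only an assay limit, > 100000 nM. Because of the limit of > 100000 nM in this assay, at which 1 of the 3 values shown sits, the steps of an at least 1.3-fold higher number from compound 1 to compound 3 (0.11 log units; that floor lies within the scatter) and an at least 5.2-fold higher number from compound 2 to compound 3 (0.72 log units; beyond the scatter) are open-ended. Compound 4 `COc1cc(C(c2ccc(O)c(OC)c2)[C@@H](C)[C@H](C)CO)ccc1O` differs from compound 1 by 2-(hydroxymethyl)-1-methylpropyl in place of 1-(methoxymethyl)-2-methylpropyl on a saturated chain carbon bound to two aromatic carbons. Compound 4 combines a shorter branch with a hydroxy group, and the two measured pulls, a 4.0-fold lower number from compound 1 to compound 2 (0.60 log units; beyond the scatter) toward stronger and an at least 5.2-fold higher number from compound 2 to compound 3 (0.72 log units; beyond the scatter) toward weaker, point in opposite directions, so little net movement is expected. Compound 4 is expected to show a step of a 1.3-fold lower number from compound 1 to compound 4 (0.10 log units; within the scatter). The estimate for compound 4 is 60000 nM, ranging from 20000 nM to 150000 nM.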

Compound 4, half-maximal inhibitory concentration: > 100000 nM
Compound 4: only a limit was reported (the forecaster's own chance of this, stated with the estimate: 30%); middle value at least 1.6-fold (0.22 log units) from the limit.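

Placed four bonds along the chain instead of three, the hydroxy group in this assay still gives an at least 5.2-fold higher number from compound 2 to compound 4 (0.72 log units; beyond the scatter), so moving it further out does not restore the strength of compound 2. Against the methoxymethyl-bearing starting point, the result is an at least 1.3-fold higher number from compound 1 to compound 4 (0.11 log units; that floor lies within the scatter), a floor too small to separate the two. The step between compound 3 and compound 4 cannot be read: the limit of > 100000 nM in this assay, at which 2 of the 4 values shown sit.

Still open, from the compounds shown here alone, is whether an amine or a carboxylic acid at that chain end would behave like the hydroxy group. Also open, going by these compounds, is whether a longer chain without oxygen would inhibit more strongly than compound 2.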